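A few compounds are considered here, and "the series" means these few. Any claim that something is new, unique, unknown or untested is made for them only; others in the source may bear on it.

In a functional assay on COR-L23 cells (Homo sapiens) for antiproliferative activity, read by CellTiter-Glo, with a stated time of 72 h (on this read-out lower numbers stand for stronger inhibition and higher numbers for weaker inhibition), compound 1 `O=C(Nc1ccc(CN2Cc3ccccc3C2=O)cc1)N1CCC(c2cccnc2)C1` gives > 2500 nM; > 2500 nM (2 entries). That entry is a limit of the assay and not a number. Compound 2 `C[C@@H](c1ccc(NC(=O)N2CC(c3ccc(N)nc3)C2)cc1)N1Cc2ccccc2C1=O` gives 19 nM. Compound 3 `COc1nc2ccccc2n1Cc1ccc(NC(=O)N2CC(c3cccnc3)C2)cc1` gives 4.3 nM, the lower of the two numbers available in the series, and its gap to compound 2 lies beyond the scatter.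

Compound 4 `CCOc1nc2ccccc2n1Cc1ccc(NC(=O)N2CC(c3cccnc3)C2)cc1` departs from compound 3 by one small change, methyl in place of hydrogen on a saturated chain carbon bound to an oxygen on an aromatic ring, which turns methoxy into ethoxy. The rest of the structure stays the same. Among the measured compounds shown here, the series holds no measured pair that shows this change, so the expectation rests only on compound 3 at 4.3 nM and on the size of the change. In this assay a slight move towards a higher number is expected, though none beyond the scatter. The estimated step is a 1.4-fold higher number from compound 3 to compound 4 (0.14 log units; within the scatter). For compound 4 the expected value is 6 nM, with an estimated range of 2 nM to 20 nM.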

Compound 4, half-maximal inhibitory concentration: 3.9 nM
Estimate against measurement, compound 4: 1.5-fold (0.19 log units) above, and the stated range covers the measured number.
By their numbers in this assay, from the lowest: compounds 4 and 3 (each within the scatter of the next); then compound 2.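

In this assay, among the compounds shown here, the pair gives a 1.1-fold lower number from compound 3 to compound 4 (0.04 log units; within the scatter), the first measured step at this position of the series. On this read-out, methoxy and ethoxy cannot be told apart, so methyl in place of hydrogen on a saturated chain carbon bound to an oxygen on an aromatic ring keeps the low nanomolar number of compound 3 in compound 4. No outside data bear on this result, and the pair alone gives no reason for it.

A single step leaves open how far this group can grow, since a longer chain such as propoxy, a branched chain such as isopropoxy and an amine in place of the alkoxy group all lie outside the compounds shown. On these data alone, it also remains open whether methoxy to ethoxy would read the same on a different core.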